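Replacing the side group of compound 1 with 3,5-dimethyl-1,2-oxazol-4-yl

A few compounds are considered here, and "the series" means these few. Any claim that something is new, unique, unknown or untested is made for them only; others in the source may bear on it.

In a physicochemical assay for lipophilicity, at pH 7.4 (a higher number here means a more lipophilic compound, a lower number a more polar compound), compound 1 `Cc1cc(C)c(CN2CCc3c(Cl)cc([C@H](CO)[C@H]4CCOC4)c(Cl)c3C2=O)c(=O)[nH]1` gives 2 as its reading. Compound 3 `COc1cc(C)[nH]c(=O)c1CN1CCc2c(Cl)cc([C@@H](O)C3COC3)c(Cl)c2C1=O` gives 1.3 on the same scale. Compound 1 stands higher than compound 3, and the gap between them lies beyond the scatter. Compound 2 `COc1cc(C)[nH]c(=O)c1CN1CCc2c(Cl)cc(C(OC)C3CCN(C(=O)CO)CC3)c(Cl)c2C1=O` gives 1.7; 1.7 (2 entries) as its reading. Compound 4 `Cc1cc(C)c(CN2CCc3c(Cl)cc(-c4c(C)noc4C)c(Cl)c3C2=O)c(=O)[nH]1` differs from compound 1 on an aromatic carbon of the core, ortho to a chloro group: a group of 7 heavy atoms (5 carbon, 1 nitrogen, 1 oxygen; one five-membered aromatic ring with 2 hetero atoms) in place of a group of 8 heavy atoms (6 carbon, 2 oxygen; one five-membered non-aromatic ring with 1 hetero atom), on an aromatic carbon is the whole change. Within the data shown here, no measured pair isolates this change, so the expectation rests on the structures alone: an upward step in this assay beyond the scatter is expected. The expected step is a number 1.10 log units higher from compound 1 to compound 4 (beyond the scatter) on this estimate. For compound 4 the estimated value is 3.1 within an expected range of 2.5 to 3.7 on this scale.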

Compound 4, distribution coefficient: 3.1
The estimate for compound 4 equals the measured number at the digits printed, within the range that was stated.
By their numbers in this assay, from the lowest: compound 3; then compound 1; then compound 4.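

In this assay, this aromatic carbon of the shared core, ortho to a chloro group, responds strongly to the side group: 3,5-dimethyl-1,2-oxazol-4-yl gives a number 1.10 log units higher from compound 1 to compound 4 (beyond the scatter) in place of the non-aromatic group. Among the compounds shown, only compound 4 has an aromatic ring directly on this carbon. No measurement shows which part of the change accounts for the step.

Open, as far as these compounds go, is how an aminopyridine or a benzoic acid on this carbon would read. Also open, from the compounds shown here alone, is whether the same change on the core of compound 3 gives a similar step.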